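A Methyl Added to the Phenyl of Compound 2

The source may hold more compounds than are shown below. What is called first, only, known or untested is meant among the compounds shown, and "the series" means these compounds.

Within the data shown here, in a functional assay on MOLT-4 cells (Homo sapiens) for antiproliferative activity, read by MTT assay, with a stated time of 72 h (a higher number here means a weaker inhibitor, a lower number a stronger inhibitor), compound 2 `O=C1C=C(N2CCC(c3ccccc3)CC2)C(=O)c2c(O)cccc21` gives 2700 nM, the only true number so far. Compound 1 `O=C1C=C(N2CCN(c3ccccc3Cl)CC2)C(=O)c2ccccc21` reaches just a limit of the assay, > 50000 nM. The next compound, compound 3 `Cc1ccccc1C1CCN(C2=CC(=O)c3cccc(O)c3C2=O)CC1`, keeps the frame of compound 2 and has methyl in place of hydrogen on an aromatic carbon, ortho to a large group, so that phenyl becomes 2-methylphenyl (methyl in place of hydrogen on an aromatic carbon). Among the measured compounds shown here, no measured pair yet shows what such a change does in this assay, so the expectation starts from compound 2 at 2700 nM. The expected change is a 1.1-fold higher number from compound 2 to compound 3 (0.05 log units; within the scatter), a small weakening that is not expected to go beyond the usual scatter. For compound 3 the estimated value is 3000 nM, with an expected range from 1000 nM to 9000 nM.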

Compound 3, half-maximal inhibitory concentration: > 50000 nM
Compound 3: no number, only a limit (the forecaster's own chance of this, stated with the estimate: 5%); middle value at least 16-fold (1.22 log units) from the limit.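

Among these compounds, changing phenyl to 2-methylphenyl gives an at least 18-fold higher number from compound 2 to compound 3 (1.26 log units; beyond the scatter) in this assay, the first measured step for this change, and it shows that a single methyl on this aromatic carbon, ortho to a large group, is enough to lose the measurable activity of compound 2. Compound 3 gives > 50000 nM, which is a limit of the assay and not a number. The full size of the step therefore stays unknown, since the reading stops at that limit: the limit of > 50000 nM in this assay, at which 2 of the 3 values shown sit.

On these data alone, it remains open whether a fluorine atom, a methoxy group or an amine on the same aromatic carbon would keep a value close to that of compound 2. Also open, as far as these compounds go, is whether a methyl placed elsewhere on that phenyl ring would have a comparable effect.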